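Three weak inhibitors and a new cinnamyl analogue

The source may report more compounds than this note shows. Statements on the series, on what has been measured and on what is new or still open speak of the compounds shown alone.

Measured compounds:
compound 1, `CCOC(=O)CCO/N=C(/c1ccc(OC)c(OC)c1OC)c1cccc2ccccc12`, 15200 nM
compound 2, `CCOC(=O)C(C)C(O)(c1ccc(OC)c(OC)c1OC)c1cccc2ccccc12`, > 20000 nM
compound 3, `COc1ccc(/C(=N/OC(C)=O)c2cccc3ccccc23)c(OC)c1OC`, 17000 nM

The three measured compounds share a core in which a trimethoxyphenyl group and a naphthalene are joined through one carbon, and all were tested in a functional assay on MDA-MB-231 cells (Homo sapiens) for inhibition, read by sulforhodamine B assay, with a stated time of 48 h; on this read-out higher numbers stand for weaker inhibition and lower numbers for stronger inhibition. Compound 1 gives 15200 nM and compound 3 gives 17000 nM. Compound 2 reaches only the limit of this assay, > 20000 nM, so for compound 2 no number is known (the limit of > 20000 nM in this assay, at which 1 of the 3 values shown sits). Going by the values given here, the single step between compounds that differ in one place, a 1.1-fold higher number from compound 1 to compound 3 (0.05 log units; within the scatter), lies within the scatter.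

The unmeasured compound 4, `COc1ccc(C(O)(C/C=C\c2ccccc2)c2cccc3ccccc23)c(OC)c1OC`, differs from compound 2 at the central carbon: 3-phenylprop-2-en-1-yl in place of 1-(ethoxycarbonyl)ethyl on a saturated chain carbon bound to two aromatic carbons and an oxygen on a saturated carbon. Among the compounds with values here, no measured step touches this position; the step from compound 1 to compound 3 changes a group on an oxygen and therefore says nothing about the carbinol carbon. What remains is that all three measured compounds sit at high numbers in this assay and that compound 2 itself is at the limit. Compound 4 is therefore expected to give about 18000 nM, within a range from 6000 nM to 50000 nM. That estimate corresponds to an expected step of an at least 1.1-fold lower number from compound 2 to compound 4 (0.04 log units; that floor lies within the scatter), with a real chance that this assay again reports only a limit.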

Compound 4, half-maximal inhibitory concentration: 12800 nM
For compound 4 the middle estimate is 1.4-fold (0.15 log units) above the measured one; the range from low to high includes it.
By their numbers in this assay, from the lowest: compounds 4, 1 and 3 (each within the scatter of the next). At a limit, above all of these: compound 2.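

The earlier compounds shown here offered no step at this carbon, and here, in this assay, compound 4 gives a number, 12800 nM, so placing 3-phenylprop-2-en-1-yl on this saturated chain carbon, in place of 1-(ethoxycarbonyl)ethyl, brings the read-out inside what the assay can report. The change itself can be stated only as a floor, an at least 1.5-fold lower number from compound 2 to compound 4 (0.19 log units; that floor lies within the scatter), and the real step may be of that size or larger. The step has only a floor because compound 2 gives no number, just a limit: the limit of > 20000 nM in this assay, at which 1 of the 4 values shown sits.

The compounds shown leave open which part of the swap matters, since the entering group brings an aromatic ring and loses the two oxygens of the leaving group, and both changes arrive together. A plain hexyl chain on the same carbon would separate these two changes, while a group ending in an amine or a carboxylic acid would test whether this position tolerates something quite different, and neither is among the compounds here.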